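Pyrrolidinyl to Dimethylamino on the Pyridyl Arm of Compound 1

The source may hold more compounds than are shown below. What is called first, only, known or untested is meant among the compounds shown, and "the series" means these compounds.

Measured so far:
compound 1 `O=C(O)Cc1sc(C(c2ccc(F)cc2)c2ccc(F)cc2)nc1-c1ccnc(N2CCCC2)c1`: > 100000 nM
compound 2 `O=C(O)Cc1sc(C(c2ccccc2)c2ccccc2)nc1-c1ccc(F)c(F)c1`: 43 nM
compound 3 `O=C(O)Cc1sc(C(c2ccccc2)c2ccc(F)c(F)c2)nc1-c1ccc(F)cc1`: 64 nM

In an in vitro functional assay on HEK285-7 cells for antagonist activity at prostaglandin D2 receptor 2 (Homo sapiens), read by BRET and beta-arrestin recruitment (a lower number here means a stronger inhibitor, a higher number a weaker inhibitor), compound 1 gives > 100000 nM, which is a limit of the assay and not a number (the limit of > 100000 nM in this assay, at which 1 of the 3 values shown sits). Compound 2 gives 43 nM and compound 3 gives 64 nM in this assay; both carry a number, whereas compound 1 does not, so compound 1 stands at the weak end of what has been measured. For the measured compounds named here, no pair of measured compounds differs in only one place, so no measured step is available to guide the next change.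

Compound 4 `CN(C)c1cc(-c2nc(C(c3ccc(F)cc3)c3ccc(F)cc3)sc2CC(=O)O)ccn1` is the next compound. It differs from compound 1 in one place: dimethylamino in place of pyrrolidin-1-yl on an aromatic carbon. Going by the values given here, with no comparable measured step, the expectation is a step from compound 1 to compound 4 of none beyond the scatter, the expected step being a number no higher from compound 1 to compound 4 (the limit leaves the size open). Compound 4 is thus estimated at 100000 nM, with a range of 20000 nM to 300000 nM, and a limit rather than a number is the more likely outcome for compound 4.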

Compound 4, half-maximal inhibitory concentration: > 100000 nM
Compound 4 was reported as a limit; the forecaster's own chance of this, stated with the estimate: 70%; the middle value sits exactly at the limit.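

In this assay compound 1 and compound 4 both stand at a limit of the assay and not at a number, so no step between them can be read: the limit of > 100000 nM in this assay, at which 2 of the 4 values shown sit.

The compounds shown leave open whether any group at this place on the shared core gives a measurable number.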